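Urea Nitrogen Substituent and Microsomal Clearance in a Fused-Ring Series

A few compounds are considered here, and "the series" means these few. Any claim that something is new, unique, unknown or untested is made for them only; others in the source may bear on it.

Measured compounds:
compound 1 `C[C@@H]1CN(Cc2ccccc2)c2ncc(F)cc2[C@H](C)N1C(=O)NCc1ccccc1` — 837 mL.min-1.g-1
compound 2 `C[C@@H]1CN(Cc2ccccc2)c2cncc(F)c2[C@H](C)N1C(=O)NCc1ccccc1` — 185 mL.min-1.g-1

In an ADME assay on liver (Homo sapiens) for metabolic stability, read by LC-MS, using microsomes and NADPH, with a stated time of 15 min, tested at 1 uM (on this read-out lower numbers stand for slow clearance and higher numbers for fast clearance), compound 1 gives 837 mL.min-1.g-1 and compound 2 gives 185 mL.min-1.g-1; compound 2 therefore stands lowest of the two numbers shown, and the gap to compound 1 lies beyond the usual scatter of repeated measurements. Among the measured compounds shown here, the two differ in the arrangement of the shared core, not in a single substituent, so no computed step between them is given here.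

Compound 3 `C[C@@H]1CN(Cc2ccccc2)c2cncc(F)c2[C@H](C)N1C(=O)Nc1cccnc1` is not yet measured. It departs from compound 2 by one change: pyridin-3-yl in place of benzyl on an amide-type nitrogen. That is, benzylamino becomes (pyridin-3-yl)amino, or benzylcarbamoyl becomes (pyridin-3-yl)carbamoyl.

For the measured compounds named here, with no measured pair showing this exact change, the expectation for compound 3 rests on compound 2 alone, whose value in this assay is 185 mL.min-1.g-1. Compound 3 is expected to show a modest step downward, a 1.5-fold lower number from compound 2 to compound 3 (0.19 log units; within the scatter), of a size near the edge of the scatter. Compound 3 is thus estimated at 120 mL.min-1.g-1, with a plausible range from 50 mL.min-1.g-1 to 300 mL.min-1.g-1.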

Compound 3, intrinsic clearance in microsomes in the Homo sapiens assay: 83 mL.min-1.g-1
For compound 3 the middle estimate is 1.4-fold (0.16 log units) above the measured one, within the range that was stated.
By their numbers in the Homo sapiens assay, from the lowest: compound 3; then compound 2; then compound 1.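

Among the compounds shown here, in the Homo sapiens assay, the first single change at this position gives a 2.2-fold lower number from compound 2 to compound 3 (0.35 log units; beyond the scatter), so the group on the amide-type nitrogen can alter the clearance read-out on the core of compound 2. For the compounds shown here, in a physicochemical assay for lipophilicity, at pH 7.4 (a higher number here means a more lipophilic compound, a lower number a more polar compound), compound 2 is recorded as "not determined" (no result reported) and compound 3 gives 3.3, so no step between them can be read in that assay. Nothing at hand bears on the reason for the change in clearance.

The compounds shown leave open whether the step belongs to the ring nitrogen or to the loss of the carbon link, which a plain phenyl or a pyridin-3-ylmethyl group on the same nitrogen would separate. They also leave open whether pyridin-3-yl gives a similar step on the core of compound 1.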